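A Methyl Cap on the Phenol of a Dinitrate Ester

This account rests on a few compounds, and the source may have more. Where it says the series, first, only, none or still open, it means among the compounds named here.

Measured so far in a functional assay on A549 cells (Homo sapiens) for cytotoxicity, read by resazurin assay, with a stated time of 72 h; on this read-out lower numbers stand for stronger inhibition and higher numbers for weaker inhibition:
compound 1, `O=C(/C=C/c1ccc(OCCCCCO[N+](=O)[O-])c(O)c1)OCCCCCO[N+](=O)[O-]`, gives 450 nM.
compound 2, `COc1cc(/C=C/C(=O)Oc2ccc(OCc3c(-c4ccccc4)no[n+]3[O-])cc2)ccc1O`, gives 3390 nM.
compound 3, `O=C(/C=C/c1ccc(O)c(O)c1)OCc1c(-c2ccccc2)no[n+]1[O-]`, gives 2710 nM.

Compound 1 holds the lowest number of the three. Its nearest neighbour on the read-out is compound 3, whose number lies beyond the scatter above it; compound 2 stands further off again, also beyond the scatter. Going by the values given here, compounds 2 and 3 each differ from compound 1 in more than one place, so their values show only where they stand and give no measured step toward the new compound.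

The unmeasured compound 4, `COc1cc(/C=C/C(=O)OCCCCCO[N+](=O)[O-])ccc1OCCCCCO[N+](=O)[O-]`, is reached from compound 1 by a single change: methyl in place of hydrogen on an oxygen on an aromatic ring. Among the compounds with values here, no pair of measured compounds shows this change alone, so its size in this assay is not known from the data. The account expects the step to be small, leaning toward a higher number, and possibly within the scatter of repeated measurement. The estimated step of a 1.6-fold higher number from compound 1 to compound 4 (0.19 log units; within the scatter) is accordingly modest. Compound 4 is expected to give about 700 nM, within a range from 300 nM to 1800 nM.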

Compound 4, half-maximal inhibitory concentration: > 50000 nM
Compound 4: a limit, no number; the forecaster's own chance of this, stated with the estimate: 3%; at least 71-fold (1.85 log units) between middle value and limit.
By their numbers in this assay, from the lowest: compound 1; then compounds 3 and 2 (each within the scatter of the next). At a limit, above all of these: compound 4.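

The hydroxy on the aromatic ring proves to be a sensitive place in this assay: hydroxy to methoxy, with only one carbon entering, brings an at least 110-fold higher number from compound 1 to compound 4 (2.04 log units; beyond the scatter), a large step beyond the scatter. On these data alone, the value of compound 4 is a limit of the assay and not a number, so the true size of the step stays unknown and only its lower end is fixed: the limit of > 50000 nM in this assay, at which 1 of the 4 values shown sits. Compound 1 and compound 4 differ in this one place only, so the pair ties the loss to this single oxygen, which compounds 2 and 3, each differing from compound 1 in more than one place, could not show.

The compounds shown leave open whether any group on that oxygen does the same, or whether methyl is a special case; an ethyl or an acetyl on the same oxygen, or an amine in place of the hydroxy, would bear on that. They also leave open how far the step runs past the limit, and whether a methyl on a hydroxy of compound 3 would have a comparable effect.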